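Solubility of Two Piperazine Amides and a Third Awaiting Measurement

The source may hold more compounds than are shown below. What is called first, only, known or untested is meant among the compounds shown, and "the series" means these compounds.

Compound 2 `O=C(c1ccccc1Cl)N1CCN(c2nc(=O)c3cc(C(F)(F)F)cc([N+](=O)[O-])c3s2)CC1`: 8.18 ug/mL
Compound 1 `O=C(c1ccc(F)cc1)N1CCN(c2nc(=O)c3cc(C(F)(F)F)cc([N+](=O)[O-])c3s2)CC1`: 1.69 ug/mL

In a physicochemical assay for solubility, read by HPLC (on this read-out higher numbers stand for higher solubility and lower numbers for lower solubility), compound 2 gives the higher of the two numbers; the step of a 4.8-fold higher number from compound 1 to compound 2 (0.68 log units; beyond the scatter) separates it from compound 1. Compound 3 `O=C(CC1CCCCC1)N1CCN(c2nc(=O)c3cc(C(F)(F)F)cc([N+](=O)[O-])c3s2)CC1` differs from compound 2 as follows: cyclohexylmethyl in place of 2-chlorophenyl on a carbonyl carbon. Within the data shown here, the only measured step, a 4.8-fold higher number from compound 1 to compound 2 (0.68 log units; beyond the scatter), swaps one aromatic ring for another and so bears only loosely on this change, which brings in a non-aromatic ring. The step of a 1.4-fold lower number from compound 2 to compound 3 (0.13 log units; within the scatter) is therefore expected to stay within the scatter, with no direction claimed. Compound 3 is estimated at 6 ug/mL, between 2 ug/mL and 20 ug/mL.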

Compound 3, solubility: 0.12 ug/mL
The estimate for compound 3 lay 50-fold (1.70 log units) above the measured number, and the stated range ends above it.
By their numbers in this assay, from the lowest: compound 3; then compound 1; then compound 2.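

In this assay the read-out turns out to depend far more on the group on the carbonyl carbon than the two aromatic compounds alone showed. Cyclohexylmethyl in place of 2-chlorophenyl gives a 68-fold lower number from compound 2 to compound 3 (1.83 log units; beyond the scatter) and in place of 4-fluorophenyl gives a 14-fold lower number from compound 1 to compound 3 (1.15 log units; beyond the scatter), both large steps, and the non-aromatic ring places compound 3 lowest of the three. Nothing measured here accounts for this.

Cyclohexylmethyl changes the ring type and the link to the carbonyl at once, so the compounds shown leave open which of the two matters. A cyclohexyl group directly on the carbonyl carbon, or a benzyl group, would separate them.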